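The source may report more compounds than this note shows. Statements on the series, on what has been measured and on what is new or still open speak of the compounds shown alone.

Measured compounds:
compound 1 `O=C(Nc1cc(C(F)(F)F)ccc1Nc1ccc(Br)cc1)c1cccnc1Cl` — 14200 nM
compound 2 `O=C(Nc1cc(C(F)(F)F)ccc1Nc1ccc(Br)cc1)c1ccccc1` — 11800 nM

In a functional assay on HL-60 cells (Homo sapiens) for cytotoxicity, read by MTT assay, with a stated time of 48 h (a lower number here means a stronger inhibitor, a higher number a weaker inhibitor), compound 1 gives 14200 nM, the highest of the two numbers; compound 2 gives 11800 nM. The step of a 1.2-fold lower number from compound 1 to compound 2 (0.08 log units; within the scatter) lies within the scatter, so the two cannot be ordered by potency. That single step concerns only the group on the carbonyl carbon.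

Compound 3 `CCN(CC)c1ccc(C(F)(F)F)cc1NC(=O)c1cccnc1Cl` differs from compound 1 at another place: diethylamino in place of (4-bromophenyl)amino on an aromatic carbon. Going by the values given here, no measured step touches this position, and a 1.2-fold lower number from compound 1 to compound 2 (0.08 log units; within the scatter) says nothing about it. With no comparison to rest on, the estimate for compound 3 is placed close to compound 1, carrying a wide range. For compound 3 the expected step is a 1.0-fold lower number from compound 1 to compound 3 (0.01 log units; within the scatter), not beyond the scatter, with the real uncertainty far larger. Compound 3 is therefore estimated at 14000 nM, with a range from 4000 nM to 50000 nM.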

Compound 3, half-maximal inhibitory concentration: 84100 nM
Beside the measured number, compound 3's estimate is 6.0-fold (0.78 log units) below it, outside the stated range (above it).
By their numbers in this assay, from the lowest: compounds 2 and 1 (each within the scatter of the next); then compound 3.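

In this assay, replacing (4-bromophenyl)amino with diethylamino gives a 5.9-fold higher number from compound 1 to compound 3 (0.77 log units; beyond the scatter) and so shows that this position can shift the number beyond the scatter, unlike the earlier change on the carbonyl carbon. The swap removes the six-membered aromatic ring of carbon only, the bromine and a hydrogen-bond donor together, so this single comparison cannot assign the shift to any one of them. Nothing available explains the shift.

Still open, as far as these compounds go, is whether phenylamino without the bromine, or a cyclic amine such as morpholine or piperidine, would stay close to compound 1 or move as compound 3 does. Also open, from the compounds shown here alone, is whether phenyl in place of 2-chloropyridin-3-yl on the carbonyl carbon would remain within the scatter with diethylamino at this position.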